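Compound 4: methyl in place of bromo

This account rests on a few compounds, and the source may have more. Where it says the series, first, only, none or still open, it means among the compounds named here.

Of the compounds shown here, three on a shared core have numbers so far. In an ADME assay on WI-38 cells (Homo sapiens) for cytotoxicity, read by sulforhodamine B assay, with a stated time of 24 h (a higher number here means a weaker inhibitor, a lower number a stronger inhibitor), compound 1 (`N#CCC(=O)N/N=C1\C(=O)Nc2ccc(S(=O)(=O)N3CCOCC3)cc21`) gives 302000 nM. In this assay compound 2 (`N=c1oc2ccccc2cc1C(=O)N/N=C1\C(=O)Nc2ccc(S(=O)(=O)N3CCOCC3)cc21`) gives 132000 nM. In this assay compound 3 (`O=C1Nc2ccc(S(=O)(=O)N3CCOCC3)cc2/C1=N/c1ccc(Br)cc1`) gives 372000 nM. That places it level with the first compound, as a 1.2-fold higher number from compound 1 to compound 3 (0.09 log units; within the scatter) shows. Compound 2 holds the lower number of the pair it forms with compound 3.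

Compound 4 (`Cc1ccc(/N=C2\C(=O)Nc3ccc(S(=O)(=O)N4CCOCC4)cc32)cc1`) is still unmeasured. It differs from compound 3 in one place: methyl in place of bromo on an aromatic carbon. This is methyl in place of bromo on an aromatic carbon, para to a large group.

Within the data shown here, no measured step changes this position, so the evidence is indirect. Exchanging the whole 4-bromophenyl group gave only a 1.2-fold higher number from compound 1 to compound 3 (0.09 log units; within the scatter). The largest measured change is modest, at a 2.3-fold lower number from compound 1 to compound 2 (0.36 log units; beyond the scatter), and it comes from a far larger replacement. A swap of one heavy atom is therefore expected to stay within the scatter, and the step expected is a 1.1-fold lower number from compound 3 to compound 4 (0.04 log units; within the scatter). The estimated value for compound 4 is 340000 nM, with an expected range of 190000 nM to 560000 nM.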

Compound 4, half-maximal inhibitory concentration: 309000 nM
The estimate for compound 4 lay 1.1-fold (0.04 log units) above the measured number; measured number inside the range.
By their numbers in this assay, from the lowest: compound 2; then compounds 1, 4 and 3 (each within the scatter of the next).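

Among these compounds, the swap of bromo for methyl gives the first direct reading at this position, on an aromatic carbon para to a large group: in this assay, it gives (a 1.2-fold lower number from compound 3 to compound 4 (0.08 log units; within the scatter)), so these two groups cannot be told apart here. The second new comparison, made on the double-bonded nitrogen, gives (a 1.0-fold higher number from compound 1 to compound 4 (0.01 log units; within the scatter)), so a second aryl group joins 4-bromophenyl in sitting level with compound 1. No available evidence bears on the reason for this flat result.

Only bromo and methyl are shown at this position, so it remains open whether an amine, a carboxylic acid or a longer chain there would also stay within the scatter of compound 3. Among the compounds shown here, also open is whether other groups on the double-bonded nitrogen could reach or pass the only step beyond the scatter so far, the modest one on the carbonyl carbon (a 2.3-fold lower number from compound 1 to compound 2 (0.36 log units; beyond the scatter)).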